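A few compounds are considered here, and "the series" means these few. Any claim that something is new, unique, unknown or untested is made for them only; others in the source may bear on it.

The measured compounds:

Compound 1, `CC1=C(C(=O)OCC(C)C)C(c2ccoc2)NC(=S)N1`: 12%
Compound 2, `CC1=C(C(=O)OC(C)(C)C)C(c2ccoc2)NC(=S)N1`: 18%
Compound 3, `CC1=C(C(=O)OCC(C)C)C(c2cccs2)NC(=O)N1C`: 9%

All three were tested in an assay on membranes from CHO cells for displacement of a labelled ligand from adenosine receptor A1 (Homo sapiens), read by scintillation counting, with a stated time of 60 min, tested at 1 uM; on this read-out higher numbers stand for more inhibition at the one concentration tested (going by the name of the read-out) and lower numbers for less inhibition. Compound 1 and compound 2 share one core and differ in a single place, (tert-butyl in place of isobutyl on an oxygen next to a carbonyl group). The step of a number 6 percentage points higher from compound 1 to compound 2 (within the scatter) is small, and the two values cannot be told apart. Compound 3 carries a different core; the difference between the two cores is not broken down here. In this assay compound 3 gives 9%, a value that sits together with those of compound 1 and compound 2, since the gaps among all three lie within the usual scatter. None of the three stands out from the others.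

Compound 4, `CC1=C(C(=O)OC(C)(C)C)C(c2cccs2)NC(=O)N1C`, has not yet been measured. It is made from compound 3 by tert-butyl in place of isobutyl on an oxygen next to a carbonyl group, the same change that turns compound 1 into compound 2, at the same place. Going by the values given here, the only guide to its effect is the step from compound 1 to compound 2, which was small. Compound 4 is therefore expected to stay close to compound 3, with an estimated step of a number 4 percentage points higher from compound 3 to compound 4 (within the scatter), because a number 6 percentage points higher from compound 1 to compound 2 (within the scatter) showed no movement beyond the scatter. In this assay compound 4 is estimated at 13%, with a likely range from 3% to 24%, resting on one pair only, so the expectation is held loosely.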

Compound 4, a percentage reported as inhibition, at one concentration (the size of the read-out at that concentration, not a potency): 18%
Estimate against measurement, compound 4: 5 percentage points below; low and high end bracket the measured number.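

In this assay, tert-butyl in place of isobutyl on an oxygen next to a carbonyl group now gives a second reading, a number 9 percentage points higher from compound 3 to compound 4 (within the scatter), and the two readings do not differ: the same change on two cores in this assay, a number 6 percentage points higher (within the scatter) from compound 1 to compound 2 and a number 9 percentage points higher (within the scatter) from compound 3 to compound 4, 3 percentage points apart, within the scatter of two such steps. So far as these two pairs go, the change carries from one core to the other, in the sense that on neither core does it move the read-out beyond the scatter. This does not show that the change raises inhibition on either core, since each step taken alone stays within the scatter, and two pairs read at one concentration say nothing about potency or about any further core.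

The compounds shown leave open whether any group at this place can lift the read-out clear of the scatter, since only isobutoxycarbonyl and tert-butoxycarbonyl appear there, and a longer chain, a benzyl ester, a carboxylic acid or an amide could behave differently. They also leave open whether the same small step would hold on a core carrying an amine, or at a higher concentration, where the values might spread further apart.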